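Imine series: replacing the hydroxy tail with ethyl

The source may hold more compounds than are shown below. What is called first, only, known or untested is meant among the compounds shown, and "the series" means these compounds.

compound 1 `O=c1[nH]c2ccccc2cc1/C=N/CCO`: 3310000 nM
compound 2 `Cc1ccc2[nH]c(=O)c(/C=N/CCO)cc2c1`: 4180000 nM

Among the measured compounds shown here, in a functional assay, read by spectrophotometry, with a stated time of 1 h (a lower number here means a stronger inhibitor, a higher number a weaker inhibitor), compound 1 gives 3310000 nM, the lower of the two numbers so far. Compound 2 gives 4180000 nM, and the step of a 1.3-fold higher number from compound 1 to compound 2 (0.10 log units; within the scatter) stays within the scatter. Compound 3 `CCCC/N=C/c1cc2ccccc2[nH]c1=O` differs from compound 1 by ethyl in place of hydroxy on a saturated chain carbon, two bonds along the chain from a double-bonded nitrogen. For the measured compounds named here, no measured step bears on this change: the only step available, a 1.3-fold higher number from compound 1 to compound 2 (0.10 log units; within the scatter), concerns a methyl on an aromatic carbon, not the chain. With nothing to suggest a shift, no step beyond the scatter is expected, a 1.0-fold lower number from compound 1 to compound 3 (0.00 log units; within the scatter). Compound 3 is therefore estimated at 3300000 nM, with a range of 1000000 nM to 11000000 nM.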

Compound 3, half-maximal inhibitory concentration: 7680000 nM
Compound 3: middle estimate off by 2.3-fold (0.37 log units), on the low side; measured number inside the range.
By their numbers in this assay, from the lowest: compounds 1, 2 and 3 (each within the scatter of the next, the first and the last beyond it).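

In this assay, among the compounds shown here, the change of hydroxy to ethyl on a saturated chain carbon, two bonds along the chain from a double-bonded nitrogen, gives the only step so far beyond the scatter: a 2.3-fold higher number from compound 1 to compound 3 (0.37 log units; beyond the scatter). The step is modest, so butyl in place of 2-hydroxyethyl costs little here, even with 0 hydrogen-bond donors and 0 hydrogen-bond acceptors in the entering ethyl. No evidence at hand explains this step.

Open, as far as these compounds go, is whether an amine or a carboxylic acid at this place would lower the number. Also open, from the compounds shown here alone, is whether a longer chain would raise it further.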